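The compounds below may be only part of what the source reports. "The series", "measured", "known", "first", "only" and "open" are said of these compounds alone.

Working notes on the series. Of the compounds shown here, three sharing the same core have numbers so far. Compound 1 `Cc1cccc(N2CCN(CCCNc3nc(NCc4ccco4)c4ccccc4n3)CC2)c1C` gives 770 nM in a functional assay on HCT-116 cells (Homo sapiens) for cytotoxicity, read by MTT assay, with a stated time of 2 days; a lower number here means a stronger inhibitor, a higher number a weaker inhibitor. Compound 2 `Fc1ccc2nc(NCCCCN3CCN(c4cccc(Cl)c4Cl)CC3)nc(NCc3ccco3)c2c1` gives 520 nM in this assay, the lowest of the three, although its gaps to compound 1 and to compound 3 both lie within the scatter. Compound 3 `Cc1cccc(N2CCN(CCCCNc3nc(NCc4ccco4)c4cc(F)ccc4n3)CC2)c1C` gives 820 nM in this assay.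

Within the data shown here, the one single-point step on record is a 1.6-fold higher number from compound 2 to compound 3 (0.20 log units; within the scatter), which concerns the aryl group on the piperazine and not the fused ring. Among the measured compounds shown here, compound 1 and compound 3 differ at two places at once, the fluoro on the fused ring and the chain length, so their values show only that the pair as a whole sits within the scatter: compound 1 gives 770 nM and compound 3 gives 820 nM.

Compound 4 `Clc1cccc(N2CCN(CCCCNc3nc(NCc4ccco4)c4ccccc4n3)CC2)c1Cl` is not yet measured. It differs from compound 2 by hydrogen in place of fluoro on an aromatic carbon. For the measured compounds named here, no measured step isolates this change; the nearest comparison, compound 1 against compound 3, gives no sign of a shift beyond the scatter. The step from compound 2 to compound 4 is therefore expected to be small, a 1.1-fold higher number from compound 2 to compound 4 (0.03 log units; within the scatter), with no clear direction. Compound 4 is expected to give about 560 nM in this assay, within a range of 250 nM to 1250 nM.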

Compound 4, half-maximal inhibitory concentration: 3200 nM
Compound 4: middle estimate off by 5.7-fold (0.76 log units), on the low side; measured number outside the range, above it.
By their numbers in this assay, from the lowest: compounds 2, 1 and 3 (each within the scatter of the next); then compound 4.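

In this assay, among these compounds, hydrogen in place of fluoro on an aromatic carbon gives a 6.2-fold higher number from compound 2 to compound 4 (0.79 log units; beyond the scatter), the first reading that isolates this position, which is meta to a fused ring and para to a fused ring. Removing this single heavy atom therefore moves the number beyond the scatter, whereas the aryl change gives a 1.6-fold higher number from compound 2 to compound 3 (0.20 log units; within the scatter), which stays within it, so within these compounds the position is not neutral when the piperazine carries 2,3-dichlorophenyl. No measurement shown here gives a reason for the step.

The compounds shown leave open whether the same step would appear with 2,3-dimethylphenyl on the piperazine, since only the fluoro form of that chain and aryl pairing has a number. They also leave open whether chloro, methoxy or nitrile at this position would behave like fluoro or like hydrogen.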